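Carboxymethyl on the Ring Nitrogen: Cytotoxicity Expectation

The compounds below may be only part of what the source reports. "The series", "measured", "known", "first", "only" and "open" are said of these compounds alone.

Measured compounds:
compound 1 `COc1ccc(-c2cc3cccc(OC)c3nc2O)cc1` with 10000 nM
compound 2 `COc1ccc(-c2cc3c(OC)ccc(OC)c3nc2O)cc1` with 10000 nM
compound 3 `COc1ccc(-c2cc3c(OC)cc(OC)cc3n(C)c2=O)cc1` with 10000 nM

In a functional assay on U-87MG ATCC cells for cytotoxicity against U-87 MG (Homo sapiens), read by colorimetric assay and MTT assay (on this read-out lower numbers stand for stronger inhibition and higher numbers for weaker inhibition), compound 1 gives 10000 nM, compound 2 gives 10000 nM and compound 3 gives 10000 nM. Compound 3 therefore stands level with compounds 1 and 2 at the digits shown. Among the measured compounds shown here, the one single-point step measured, no change at the digits printed from compound 1 to compound 2 (within the scatter), came with methoxy in place of hydrogen on an aromatic carbon and did not move the read-out beyond the scatter.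

Compound 4 `COc1ccc(-c2cc3c(OC)cc(OC)cc3n(CC(=O)O)c2=O)cc1` is not yet measured. It differs from compound 3 by carboxy in place of hydrogen on a saturated chain carbon bound to an aromatic nitrogen. For the measured compounds named here, none of the measured steps touches the substituent on the aromatic nitrogen, so the one step known, methoxy in place of hydrogen on an aromatic carbon, bears on this change only loosely, and it was flat. With all three measured compounds sitting at the same level, no movement beyond the scatter is expected in this assay; the step of no change at the digits printed from compound 3 to compound 4 (within the scatter) is estimated as flat. Compound 4 is therefore expected to give 10000 nM, within 5000 nM to 20000 nM.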

Compound 4, half-maximal inhibitory concentration: 10000 nM
For compound 4 middle estimate and measured number coincide at the digits printed; the range from low to high includes it.
By their numbers in this assay, from the lowest: compounds 1, 2, 3 and 4 (each within the scatter of the next).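

Among the compounds shown here, this is the first measured change to the substituent on the aromatic nitrogen: going from methyl to carboxymethyl gives no change at the digits printed from compound 3 to compound 4 (within the scatter) in this assay. Placing carboxy on the saturated chain carbon bound to the aromatic nitrogen therefore does not separate the two compounds on this read-out, so this position accepts the added group without a visible shift in the number. Nothing available here explains why the step is flat.

The compounds shown leave open whether a different group on the aromatic nitrogen, such as an aminoethyl chain or a longer chain ending in a carboxylic acid, would move the number in this assay. All four compounds print the same value, so they do not show which change to the shared core, if any, could lower it.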